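The source may hold more compounds than are shown below. What is called first, only, known or untested is meant among the compounds shown, and "the series" means these compounds.

Measured so far:
compound 1, `COc1ccc(/C=C/C(=O)c2ccc(OCC=C(C)C)cc2O)cc1OC`: > 100000 nM
compound 2, `COc1ccc(/C=C/C(=O)c2ccc(OCC=C(C)C)cc2OCC=C(C)C)c(OC)c1OC`: 49000 nM

In an assay on isolated protein for inhibition of Polyunsaturated fatty acid 5-lipoxygenase (Homo sapiens) (a lower number here means a stronger inhibitor, a higher number a weaker inhibitor), compound 1 gives > 100000 nM, which is a limit of the assay rather than a number. Among the measured compounds shown here, compound 2 gives 49000 nM, the only number recorded here. The other result sits at the limit of > 100000 nM in this assay, at which 1 of the 2 values shown sits. Compound 3, `COc1ccc(/C=C/C(=O)c2ccc(OCC=C(C)C)cc2OCC=C(C)C)cc1OC`, differs from compound 2 by hydrogen in place of methoxy on an aromatic carbon. For the measured compounds named here, no measured step of this kind exists, so the change is expected to be small, a 1.2-fold higher number from compound 2 to compound 3 (0.09 log units; within the scatter), not clearly beyond the usual scatter. Compound 3 is expected to give about 60000 nM, with a likely range from 20000 nM to 200000 nM.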

Compound 3, half-maximal inhibitory concentration: 9000 nM
The estimate for compound 3 lay 6.7-fold (0.82 log units) above the measured number; the measured number lies below the stated range.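

In this assay, replacing this methoxy, which sits on an aromatic carbon ortho to a large group, with hydrogen gives a 5.4-fold lower number from compound 2 to compound 3 (0.74 log units; beyond the scatter), so this position is sensitive to what it carries. Compound 1 stands at a limit of the assay, not at a number: the limit of > 100000 nM in this assay, at which 1 of the 3 values shown sits. Putting 3-methylbut-2-en-1-yl in place of hydrogen on the oxygen on the aromatic ring gives an at least 11-fold lower number from compound 1 to compound 3 (1.04 log units; beyond the scatter), so that second chain also matters.

Open, as far as these compounds go, is whether a fluorine or an amine at the methoxy position would match hydrogen. Also open, from the compounds shown here alone, is what the two remaining methoxy groups contribute.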